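A few compounds are considered here, and "the series" means these few. Any claim that something is new, unique, unknown or untested is made for them only; others in the source may bear on it.

Measured in a functional assay on LNCaP cells (Homo sapiens) for cytotoxicity; a lower number here means a stronger inhibitor, a higher number a weaker inhibitor:
Compound 1 `CNC(=O)Nc1ccc(-c2nc(N3CC4CCC(C3)O4)c3cnn(C)c3n2)cc1`: 170 nM
Compound 2 `O=C(Nc1ccccc1)Nc1ccc(-c2nc(N3CC4CCC(C3)O4)c3cnn(C4CCC5(CC4)OCCO5)c3n2)cc1`: 4 nM
Compound 3 `CNC(=O)Nc1ccc(-c2nc(N3CC4CCC(C3)O4)c3cnn([C@H]4CC[C@@H](OC)CC4)c3n2)cc1`: 1 nM

Compound 2, at 4 nM, holds the second highest of the three numbers. Compound 4 `O=C(Nc1ccc(-c2nc(N3CC4CCC(C3)O4)c3cnn(C4CCC5(CC4)OCCO5)c3n2)cc1)NC1CC1` departs from it as follows: cyclopropyl in place of phenyl on an amide-type nitrogen. Going by the values given here, the only measured step, a 170-fold lower number from compound 1 to compound 3 (2.23 log units; beyond the scatter), is large but concerns 4-methoxycyclohexyl in place of methyl on an aromatic nitrogen, so it says little about this change. Compound 3 has methyl rather than phenyl on the amide-type nitrogen and gives 1 nM, though it also differs elsewhere. In this assay, no step beyond the scatter is therefore expected, if anything a slightly lower number. The estimated step is a 1.6-fold lower number from compound 2 to compound 4 (0.20 log units; within the scatter). For compound 4 the expected value is 2.5 nM, with an estimated range of 0.8 nM to 8 nM.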

Compound 4, half-maximal inhibitory concentration: 2 nM
For compound 4 the middle estimate is 1.3-fold (0.10 log units) above the measured one; measured number inside the range.
By their numbers in this assay, from the lowest: compounds 3, 4 and 2 (each within the scatter of the next, the first and the last beyond it); then compound 1.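

In this assay, cyclopropyl in place of phenyl on the amide-type nitrogen gives a 2.0-fold lower number from compound 2 to compound 4 (0.30 log units; within the scatter), the first step read at this position, so the assay does not separate a six-membered aromatic ring from a three-membered non-aromatic ring here. No measurement shown explains why these two groups read alike.

On these data alone, whether a hydroxyethyl chain, a carboxylic acid or a basic amine on this nitrogen would stay in the same range remains open. So does whether the same exchange would read alike with 4-methoxycyclohexyl on the aromatic nitrogen.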